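An Alkylamino Swap Expected to Restore Potency

The compounds below may be only part of what the source reports. "The series", "measured", "known", "first", "only" and "open" are said of these compounds alone.

Of the compounds shown here, three sharing one core have been tested in a functional assay on T-24 cells (Homo sapiens) for antiproliferative activity, read by MTT assay, with a stated time of 72 h; on this read-out higher numbers stand for weaker inhibition and lower numbers for stronger inhibition. Compound 1 `N=C(NC(=N)NC1CCCC1)Nc1ccc(C(F)(F)F)cc1` gives 3700 nM. Compound 2 `CCCCCCCNC(=N)NC(=N)Nc1ccc(F)c(F)c1` gives 4300 nM. Compound 3 `CCN(CC)C(=N)NC(=N)Nc1ccc(F)c(F)c1` gives 44800 nM, the highest of the three numbers; its gaps to compound 2 and to compound 1 both lie beyond the usual scatter, so compound 3 is the weakest inhibitor of the set.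

Compound 4 `CC(C)CNC(=N)NC(=N)Nc1ccc(F)c(F)c1` has not yet been measured. It differs from compound 3 in one place: isobutylamino in place of diethylamino on a carbon with a double bond to nitrogen. Going by the values given here, no pair among the measured compounds isolates this change, so the expectation rests on the spread of the three numbers: compound 2 and compound 1 sit far below compound 3 in this assay, and compound 4 carries a secondary alkylamino group as they do rather than the tertiary one of compound 3. A sizeable drop in the number, well beyond the scatter, is therefore expected from compound 3 to compound 4, that is a 5.6-fold lower number from compound 3 to compound 4 (0.75 log units; beyond the scatter). Compound 4 is estimated at 8000 nM in this assay, within a range from 2500 nM to 25000 nM.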

Compound 4, half-maximal inhibitory concentration: 42900 nM
Compound 4: middle estimate off by 5.4-fold (0.73 log units), on the low side; measured number outside the range, above it.
By their numbers in this assay, from the lowest: compounds 1 and 2 (each within the scatter of the next); then compounds 4 and 3 (each within the scatter of the next).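

In this assay isobutylamino in place of diethylamino on a carbon with a double bond to nitrogen gives a 1.0-fold lower number from compound 3 to compound 4 (0.02 log units; within the scatter) and so does not separate the two compounds, even though the entering group counts one hydrogen-bond donor and the leaving group none. Isopropyl in place of hexyl on a saturated chain carbon bound to an amine nitrogen gives a 10-fold higher number from compound 2 to compound 4 (1.00 log units; beyond the scatter) and thus marks a large change with both compounds carrying the same secondary amino arrangement. Among these compounds, having that arrangement is therefore not enough to reach the lower numbers, and the alkyl chain attached to it makes the difference. Nothing shown explains either step.

The compounds shown leave open how a straight butyl, pentyl or octyl chain would compare on the same core. They also leave open whether a cyclohexyl ring at this position would behave like hexyl or like isopropyl.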